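Adding a Chloro Group to a Weakly Active Hydrazone

The compounds below may be only part of what the source reports. "The series", "measured", "known", "first", "only" and "open" are said of these compounds alone.

Compound 2 `Cn1c(=O)c(=O)n(C2CCCC2)c2nc(N/N=C/c3cccc([N+](=O)[O-])c3)ncc21` is tested in a functional assay on HCT-116 cells (Homo sapiens) for antiproliferative activity, read by MTT assay (a lower number here means a stronger inhibitor, a higher number a weaker inhibitor), where compound 2 gives 15200 nM. Among the measured compounds shown here, its only measured relative is compound 1 `Cn1c(=O)c(=O)n(C2CCCC2)c2nc(N/N=C/c3ccc(C(F)(F)F)cc3)ncc21`, which carries a 4-(trifluoromethyl)phenyl instead of the 3-nitrophenyl; in this assay compound 1 gives 29000 nM. The measured step is a 1.9-fold lower number from compound 1 to compound 2 (0.28 log units; within the scatter), so the two numbers cannot be told apart. Compound 3 `Cn1c(=O)c(=O)n(C2CCCC2)c2nc(N/N=C/c3cc([N+](=O)[O-])ccc3Cl)ncc21` has not yet been measured. It differs from compound 2 by chloro in place of hydrogen on an aromatic carbon, sitting on an aromatic carbon of a six-membered aromatic ring of carbon only, ortho to a large group and para to the nitro group. For the measured compounds named here, no measured step adds a chloro group, and the single step that exists stayed within the scatter. The step of a 1.0-fold lower number from compound 2 to compound 3 (0.01 log units; within the scatter) is therefore expected to be small, with no direction that can be called. Compound 3 is estimated at 15000 nM, with a range from 6000 nM to 40000 nM.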

Compound 3, half-maximal inhibitory concentration: 5610 nM
The estimate for compound 3 lay 2.7-fold (0.43 log units) above the measured number; the whole stated range lies above it.
By their numbers in this assay, from the lowest: compound 3; then compounds 2 and 1 (each within the scatter of the next).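

In this assay, placing a chloro group on the aromatic carbon ortho to a large group and para to the nitro group gives a 2.7-fold lower number from compound 2 to compound 3 (0.43 log units; beyond the scatter) and so, unlike the swap between compound 1 and compound 2, clears the scatter. This shows that a single added atom at this ring position can shift the number, though only modestly. The change from 4-(trifluoromethyl)phenyl to 2-chloro-5-nitrophenyl gives a 5.2-fold lower number from compound 1 to compound 3 (0.71 log units; beyond the scatter) and is also beyond the scatter. Nothing here explains why the number falls.

The compounds shown leave open whether a methyl group, a methoxy group or an amine at this position would do the same as chloro. From the compounds shown here alone, the chloro group also appears only alongside the nitro group, so whether its step holds without that group remains unknown.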